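This account rests on a few compounds, and the source may have more. Where it says the series, first, only, none or still open, it means among the compounds named here.

The measured compounds, each read in a functional assay (aorta) with Rattus norvegicus as the target; on this read-out lower numbers stand for an effect already at smaller amounts and higher numbers for an effect only at larger amounts of compound:

compound 1, `COc1ccccc1NC(=O)NC1CC(C)(C)Oc2ccc(Cl)cc21`, gives only a limit, > 10000 nM.
compound 2, `COc1ccccc1NC(=O)NC1CC(C)(C)Oc2ccc(Br)cc21`, gives only a limit, > 10000 nM.
compound 3, `COc1ccc(NC(=O)NC2CC(C)(C)Oc3ccc(Cl)cc32)cc1`, gives only a limit, > 30000 nM.

None of the three reaches a number in this assay. Compound 1 and compound 2 differ by bromo in place of chloro on an aromatic carbon, and the step between them is a step that the two limits leave unreadable from compound 1 to compound 2; it cannot be sized because the limit of > 10000 nM in this assay, at which 2 of the 3 values shown sit, is all that both of them show. Compound 1 and compound 3 differ in the core by 4-methoxyphenyl in place of 2-methoxyphenyl on an amide-type nitrogen, and the step between them is a step that the two limits leave unreadable from compound 1 to compound 3; here too nothing can be read because the limit of > 10000 nM in this assay, at which 2 of the 3 values shown sit, on one side and the limit of > 30000 nM in this assay, at which 1 of the 3 values shown sits, on the other side are limits, not numbers.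

Compound 4, `COc1ccc(NC(=O)NC2CC(C)(C)Oc3ccc(Br)cc32)cc1`, has not yet been measured. It differs from compound 3 by bromo in place of chloro on an aromatic carbon, the same change that separates compound 1 from compound 2, at a place described in the same words for both pairs. That earlier step gave no readable size, and compound 3 itself sits at a limit, so the expectation for compound 4 is that it will again fall at or beyond a limit in this assay. The step from compound 3 to compound 4 is expected to be a number no higher from compound 3 to compound 4 (the limit leaves the size open), resting only on the unreadable earlier step and on the limit shown by compound 3. For compound 4 the estimate is 30000 nM, ranging from 10000 nM to 100000 nM.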

Compound 4, half-maximal effective concentration: > 10000 nM
Compound 4 gave a limit, no number (the forecaster's own chance of this, stated with the estimate: 85%); the middle value is on the limit's open side.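

Compound 4 gives only a limit in this assay, and compound 2 and compound 3 also show limits, not numbers; neither the step from compound 3 to compound 4 nor the step from compound 2 to compound 4 can be read. The compounds shown leave open whether bromo in place of chloro, or 4-methoxyphenyl in place of 2-methoxyphenyl, changes the half-maximal effective concentration at all.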